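The compounds below may be only part of what the source reports. "The series", "measured", "known", "first", "only" and "open" are said of these compounds alone.

Three members of the series have been run so far in an ADME assay on 184B5 cells (Homo sapiens) for cytotoxicity, read by sulforhodamine B assay, with a stated time of 48 h; a lower number here means a stronger inhibitor of growth, a higher number a weaker inhibitor of growth. Compound 1 `O=C1C(=O)N(CN2CCN(c3ccnc4cc(Cl)ccc34)CC2)c2cccc(Br)c21` gives 49000 nM, compound 2 `O=C1C(=O)N(CN2CCN(c3ccnc4cc(Cl)ccc34)CC2)c2cc(Cl)ccc21` gives 47500 nM, and compound 3 `O=C1C(=O)N(CN2CCN(c3ccnc4cc(C(F)(F)F)ccc34)CC2)c2cccc(Br)c21` gives 49700 nM. How the core of compound 2 differs from that of compound 1 is not broken down here; the two values lie within the scatter of each other. Compound 3 carries trifluoromethyl in place of chloro on an aromatic carbon relative to compound 1, a step of a 1.0-fold higher number from compound 1 to compound 3 (0.01 log units; within the scatter). Compound 4 `O=C1C(=O)N(CN2CCN(c3ccnc4cc(C(F)(F)F)ccc34)CC2)c2cc(Cl)ccc21` has not yet been measured; it carries the same change on compound 2, namely (trifluoromethyl in place of chloro on an aromatic carbon). Because the earlier step measured a 1.0-fold higher number from compound 1 to compound 3 (0.01 log units; within the scatter), the step from compound 2 to compound 4 is expected to be a 1.0-fold higher number from compound 2 to compound 4 (0.00 log units; within the scatter). The value of compound 4 in this assay is estimated at 48000 nM, with a likely range from 30000 nM to 78000 nM.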

Compound 4, concentration for 50% growth inhibition: 25300 nM
Estimate against measurement, compound 4: 1.9-fold (0.28 log units) above; measured number below the stated range.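

In this assay, trifluoromethyl in place of chloro on an aromatic carbon gives a 1.9-fold lower number from compound 2 to compound 4 (0.27 log units; within the scatter). Set beside the earlier step, the change carries from one core to the other with no difference that can be told from the scatter: the same change on two cores in this assay, a 1.0-fold higher number (0.01 log units; within the scatter) from compound 1 to compound 3 and a 1.9-fold lower number (0.27 log units; within the scatter) from compound 2 to compound 4, 1.9-fold (0.28 log units) apart, within the scatter of two such steps. This shows no dependence on the core across these two pairs, but it does not show that the change is without effect, and two pairs set no rule for other cores in the series.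

The compounds shown leave open whether an amine, a carboxylic acid or a nitrile on the same aromatic carbon would give a step beyond the scatter. Also open, going by these compounds, is whether the same change reads alike on a core carrying a methoxy group.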